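Pyridinium in place of a bicyclic cation on the chain

The compounds below may be only part of what the source reports. "The series", "measured", "known", "first", "only" and "open" are said of these compounds alone.

Measured compounds:
compound 1 `Cc1cc(OCCCCCCC[N+]23CCN(CC2)CC3)cc(-n2cc(C(=O)Nc3cc(F)cc(F)c3)c(=O)c3ccc(N(C)C)nc32)c1` — 5.52%
compound 2 `Cc1cc(-n2cc(C(=O)Nc3cc(F)cc(F)c3)c(=O)c3ccc(N(C)C)nc32)ccc1OCCCCCCC[N+]1(C)CCCCC1` — 54.4%
compound 3 `CN(C)c1ccc2c(=O)c(C(=O)Nc3cc(F)cc(F)c3)cn(-c3ccc(OCCCCCCC[N+]4(C)CCCCC4)c(Cl)c3)c2n1` — "not active" (no number reported)

In an assay on LX2 cells for inhibition of COL1A1 promoter (Homo sapiens), read by a luciferase reporter, with a stated time of 24 h, tested at 50 uM (on this read-out lower numbers stand for a weaker effect and higher numbers for a stronger effect at the one concentration tested), compound 1 gives 5.52%, the lowest of the two numbers recorded. Its nearest neighbour is compound 2, which in this assay gives 54.4%, a gap well beyond the scatter of this read-out. Compound 3 carries no number; in this assay compound 3 is reported as "not active" (no number reported). No pair of these compounds differs in only one place, so no measured step is available to lean on.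

Compound 4 `Cc1cc(OCCCCCCC[n+]2ccccc2)cc(-n2cc(C(=O)Nc3cc(F)cc(F)c3)c(=O)c3ccc(N(C)C)nc32)c1` is the untested member of the set. It differs from compound 1 as follows: a group of 6 heavy atoms (5 carbon, 1 nitrogen; one six-membered aromatic ring with 1 hetero atom) in place of a group of 8 heavy atoms (6 carbon, 2 nitrogen; 2 six-membered non-aromatic rings with 2 hetero atoms each), on a saturated chain carbon, seven bonds along the chain from an oxygen on an aromatic ring. The shared core, the difluorophenyl amide and the seven-carbon chain from the aromatic oxygen are kept; only the charged group at the end of the chain is exchanged.

Among the measured compounds shown here, with no measured step of this kind, the account rests on compound 1 alone and on the fact that the terminal cation is the sole change. The expected step of a number 12.5 percentage points higher from compound 1 to compound 4 (beyond the scatter) is a modest rise, though a result within the scatter of compound 1 would not surprise. Compound 4 is therefore estimated to give 18%, with a range from 0% to 50%.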

Compound 4, a percentage reported as inhibition, at one concentration (the size of the read-out at that concentration, not a potency): 61%
The estimate for compound 4 lay 43 percentage points below the measured number; the whole stated range lies below it.
By their numbers in this assay, from the lowest: compound 1; then compounds 2 and 4 (each within the scatter of the next).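

In this assay, among the compounds shown here, the exchange at the end of the chain, on a saturated chain carbon, seven bonds along the chain from an oxygen on an aromatic ring, gives a number 55.5 percentage points higher from compound 1 to compound 4 (beyond the scatter), a large step and the only measured step between compounds that differ in one place. It shows that the read-out at this position responds strongly to the identity of the terminal group: one six-membered aromatic ring with 1 hetero atom replaces 2 six-membered non-aromatic rings with 2 hetero atoms each, while the net charge stays at +1 on both sides of the exchange. The groups also differ in heavy atoms and in hydrogen-bond acceptors, but no measurement shown here separates these differences or explains the step.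

The compounds shown leave open whether a positive charge at the chain end is needed at all, a question that a piperidine or another tertiary amine in that place could address. They also leave open whether the step would hold with a quinolinium group at the chain end or with a longer chain bearing the same pyridinium group.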